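The compounds below may be only part of what the source reports. "The series", "measured", "known", "first", "only" and "open" are said of these compounds alone.

In an ADME assay on NIH3T3 cells (Mus musculus) for cytotoxicity, read by MTT assay, with a stated time of 24 h (on this read-out lower numbers stand for stronger inhibition and higher numbers for weaker inhibition), three compounds have been measured so far:

compound 1 `O=C(CSc1nnc(-c2ccncc2)o1)N/N=C/c1ccccc1` — 167000 nM
compound 2 `O=C(CSc1nnc(-c2ccncc2)o1)N/N=C/c1ccc(O)cc1` — 158000 nM
compound 3 `O=C(CSc1nnc(-c2ccncc2)o1)N/N=C/c1ccccc1O` — 155000 nM

Compound 2 gives the second highest of the three numbers in this assay. Its nearest neighbour is compound 3, and the step of a 1.0-fold lower number from compound 2 to compound 3 (0.01 log units; within the scatter) lies within the scatter; the step of a 1.1-fold lower number from compound 1 to compound 2 (0.02 log units; within the scatter) is likewise within the scatter, as is a 1.1-fold lower number from compound 1 to compound 3 (0.03 log units; within the scatter). Among the compounds with values here, all three numbers therefore sit at one level, and nothing among the measured compounds separates them.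

The unmeasured compound 4 `O=C(CSc1nnc(-c2ccncc2)o1)N/N=C/c1cc(Cl)cc(Cl)c1O` differs from compound 2 in one place: 3,5-dichloro-2-hydroxyphenyl in place of 4-hydroxyphenyl on a carbon with a double bond to nitrogen. The measured steps that bear on this change are the hydroxy additions a 1.1-fold lower number from compound 1 to compound 2 (0.02 log units; within the scatter) and a 1.1-fold lower number from compound 1 to compound 3 (0.03 log units; within the scatter), which both stayed within the scatter, and the move of the hydroxy group a 1.0-fold lower number from compound 2 to compound 3 (0.01 log units; within the scatter), which also stayed within the scatter. Within the data shown here, no measured step covers the entry of two chlorines, so that part of the change has no precedent here. In this assay the expected step is estimated as a 1.4-fold lower number from compound 2 to compound 4 (0.16 log units; within the scatter), that is, a small step that stays within the scatter.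

Compound 4 is therefore estimated at 110000 nM, with a range from 45000 nM to 260000 nM.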

Compound 4, half-maximal inhibitory concentration: 171000 nM
Compound 4: the middle estimate sits 1.6-fold (0.19 log units) below what was measured; measured number inside the range.
By their numbers in this assay, from the lowest: compounds 3, 2, 1 and 4 (each within the scatter of the next).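

In this assay, within the data shown here, the entry of two chlorines, the one part of the change that had no precedent among the earlier compounds, still leaves the number at the same level, with a 1.1-fold higher number from compound 2 to compound 4 (0.03 log units; within the scatter) and a 1.1-fold higher number from compound 3 to compound 4 (0.04 log units; within the scatter) and also a 1.0-fold higher number from compound 1 to compound 4 (0.01 log units; within the scatter) all lying within the scatter. The place on a carbon with a double bond to nitrogen thus now carries phenyl, 4-hydroxyphenyl, 2-hydroxyphenyl and 3,5-dichloro-2-hydroxyphenyl with nothing to separate them, so the larger group does not set compound 4 apart from the other three. Nothing available here gives a reason for this single level.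

The compounds shown leave open whether the level would hold with a group of another kind on this aromatic ring, such as an amine, a carboxylic acid or a longer alkoxy chain. They also leave open what a chlorine would do on a phenyl that carries no hydroxy group, and whether one chlorine alone would give the same number as two.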